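Phenyl in place of methyl on compound 3

A few compounds are considered here, and "the series" means these few. Any claim that something is new, unique, unknown or untested is made for them only; others in the source may bear on it.

Measured in a functional assay on the whole organism with Rattus norvegicus as the target; a lower number here means that less compound is needed, a higher number that more compound is needed for the effect:
Compound 1 `CCOCCOC(=O)C(=O)Nc1nc(-c2cc(C)on2)cs1`: 1.3 mg/kg
Compound 2 `CCOCCOC(=O)C(=O)Nc1nc(-c2cc(-c3ccccc3)on2)cs1`: 0.2 mg/kg
Compound 3 `Cc1cc(-c2csc(NC(=O)C(=O)O)n2)no1`: 1.7 mg/kg

The step of a 1.3-fold higher number from compound 1 to compound 3 (0.12 log units; within the scatter) leaves compound 3 level with compound 1 at the high end of these numbers, and compound 2 lies well under both. Compound 4 `O=C(O)C(=O)Nc1nc(-c2cc(-c3ccccc3)on2)cs1` differs from compound 3 by phenyl in place of methyl on an aromatic carbon, which is phenyl in place of methyl on an aromatic carbon. The same exchange has been measured only once, as a 6.5-fold lower number from compound 1 to compound 2 (0.81 log units; beyond the scatter). On these data alone, whether it carries over to compounds with hydrogen in place of 2-ethoxyethyl is untested. A step of similar size towards a lower number is nevertheless expected, a 5.7-fold lower number from compound 3 to compound 4 (0.75 log units; beyond the scatter). For compound 4 the estimate is 0.3 mg/kg, with an expected range of 0.1 mg/kg to 0.9 mg/kg.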

Compound 4, dose for half-maximal effect: 0.23 mg/kg
Compound 4: the middle estimate sits 1.3-fold (0.12 log units) above what was measured, and the stated range covers the measured number.
By their numbers in this assay, from the lowest: compounds 2 and 4 (each within the scatter of the next); then compounds 1 and 3 (each within the scatter of the next).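

In this assay phenyl in place of methyl on this aromatic carbon, next to the ring oxygen, also lowers the number without the 2-ethoxyethyl group (a 7.4-fold lower number from compound 3 to compound 4 (0.87 log units; beyond the scatter)). The exchange therefore holds on both cores: the same change on two cores in this assay, a 6.5-fold lower number (0.81 log units; beyond the scatter) from compound 1 to compound 2 and a 7.4-fold lower number (0.87 log units; beyond the scatter) from compound 3 to compound 4, 1.1-fold (0.06 log units) apart, within the scatter of two such steps. Hydrogen in place of 2-ethoxyethyl, until now seen only with methyl, also leaves the number level with phenyl (a 1.2-fold higher number from compound 2 to compound 4 (0.06 log units; within the scatter)), so that pair matches too: the same change on two cores in this assay, a 1.3-fold higher number (0.12 log units; within the scatter) from compound 1 to compound 3 and a 1.2-fold higher number (0.06 log units; within the scatter) from compound 2 to compound 4, 1.1-fold (0.06 log units) apart, within the scatter of two such steps.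

On these data alone, whether a smaller group such as ethyl, or an amine, on this carbon would fall in line remains open. So does the effect of a substituted phenyl there.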